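One Methyl Less: From Compound 1 to Compound 4

The compounds below may be only part of what the source reports. "The series", "measured", "known", "first", "only" and "open" are said of these compounds alone.

Compound 1 `Cc1ccc(CN2C(=O)N(Cc3ccccc3)S(=O)(=O)n3cccc32)cc1` is the only one of the three measured compounds that gives a number in an ADME assay on MT4 cells (Homo sapiens) for cytotoxicity, read by MTT assay, with a stated time of 5 days; a lower number here means that less compound is tolerated, a higher number that more compound is tolerated; compound 1 gives 241000 nM. Compound 2 `C=CCN1C(=O)N(Cc2ccccc2)S(=O)(=O)n2cccc21` reaches only a limit of the assay, > 802000 nM. Compound 3 `O=C1N(Cc2ccccc2Cl)c2cccn2S(=O)(=O)N1Cc1cccc(Br)c1` likewise reaches only a limit, > 260000 nM. Within the data shown here, the only measured step is an at least 3.3-fold higher number from compound 1 to compound 2 (0.52 log units; beyond the scatter). That step rests on a limit, (the limit of > 802000 nM in this assay, at which 1 of the 3 values shown sits), so its full size is not known.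

Compound 4 `O=C1N(Cc2ccccc2)c2cccn2S(=O)(=O)N1Cc1ccccc1` differs from compound 1 as follows: hydrogen in place of methyl on an aromatic carbon. Among the measured compounds shown here, no measured step matches this change directly. The step from compound 1 to compound 2 exchanges the whole 4-methylphenyl for vinyl and gives only a direction, towards more compound being tolerated. Dropping a single methyl is a far smaller change, so the expected step for compound 4 is small, a 1.2-fold higher number from compound 1 to compound 4 (0.10 log units; within the scatter), most likely within the scatter. Compound 4 is estimated at 300000 nM, with a range from 150000 nM to 600000 nM.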

Compound 4, half-maximal cytotoxic concentration: 196000 nM
Beside the measured number, compound 4's estimate is 1.5-fold (0.18 log units) above it; the measured number falls inside the stated range.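

Removing the methyl from the 4-methylphenyl gives a 1.2-fold lower number from compound 1 to compound 4 (0.09 log units; within the scatter) in this assay, so on this aromatic carbon the change from 4-methylphenyl to phenyl has no readable effect. Among these compounds, this is the first step with a full size rather than only a direction, and it shows that the methyl alone does not separate compound 1 from compound 4 in this assay. With the methyl gone, the exchange of vinyl for phenyl gives an at least 4.0-fold lower number from compound 2 to compound 4 (0.61 log units; beyond the scatter), a step beyond the scatter whose full size remains unknown, as it rests on a limit: the limit of > 802000 nM in this assay, at which 1 of the 4 values shown sits.

The compounds shown leave open whether an amine, a carboxylic acid or a longer chain on this aromatic carbon would move the number beyond the scatter. On these data alone, how far compound 2 truly lies from compound 4 also stays open.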